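Phenyl in Place of Thiophen-2-yl on Two Cores

This account rests on a few compounds, and the source may have more. Where it says the series, first, only, none or still open, it means among the compounds named here.

Compound 1 `Cc1nc(N)c2c(-c3ccccc3)cn([C@@H]3O[C@H](CO)[C@@H](O)[C@H]3O)c2n1` and compound 2 `Cc1nc(N)c2c(-c3cccs3)cn([C@@H]3O[C@H](CO)[C@@H](O)[C@H]3O)c2n1` share one core. In a functional assay on HCT-116 cells (Homo sapiens), read by MTT assay, with a stated time of 72 h (on this read-out lower numbers stand for stronger inhibition and higher numbers for weaker inhibition), compound 2 reaches only the assay limit of > 20000 nM. Compound 1 likewise gives only a limit, > 20000 nM. The change between them, (phenyl in place of thiophen-2-yl on an aromatic carbon), therefore yields a step that the two limits leave unreadable from compound 2 to compound 1, because both values sit at the limit of > 20000 nM in this assay, at which 2 of the 3 values shown sit.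

Compound 3 `COc1ncnc2c1c(-c1cccs1)cn2[C@@H]1O[C@H](CO)[C@@H](O)[C@H]1O` carries another core; the difference between the two cores is not broken down here. In this assay compound 3 gives 440 nM. Compound 4 `COc1ncnc2c1c(-c1ccccc1)cn2[C@@H]1O[C@H](CO)[C@@H](O)[C@H]1O` is compound 3 with phenyl in place of thiophen-2-yl on an aromatic carbon, the same change as from compound 2 to compound 1. The step from compound 3 to compound 4 is expected to be a 1.8-fold higher number from compound 3 to compound 4 (0.26 log units; within the scatter), resting only on compound 3 at 440 nM, since the earlier step is unreadable. Compound 4 is thus estimated at 800 nM, within 200 nM to 4000 nM.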

Compound 4, half-maximal inhibitory concentration: > 20000 nM
Compound 4: only a limit was reported (the forecaster's own chance of this, stated with the estimate: 5%); middle value at least 25-fold (1.39 log units) away from the limit.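

In this assay, phenyl in place of thiophen-2-yl on the core of compound 3 gives an at least 45-fold higher number from compound 3 to compound 4 (1.65 log units; beyond the scatter), and since compound 4 has only a limit, the true step may be larger still. The same change from compound 2 to compound 1 cannot be read, so nothing can be said about whether its effect carries from one core to the other, because both values are limits: the limit of > 20000 nM in this assay, at which 3 of the 4 values shown sit. The large step therefore stands for one core only.

The compounds shown leave open how a furan-2-yl or thiophen-3-yl group would read on this aromatic carbon of the core of compound 3, which gives 440 nM with its thiophen-2-yl. They also leave open whether an aminomethyl group there would bring the core of compound 1 to a readable value.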